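The compounds below may be only part of what the source reports. "The series", "measured", "known", "first", "only" and "open" are said of these compounds alone.

Of the compounds shown here, two sharing one core have so far been measured in an assay on isolated protein for inhibition of ribosomal protein S6 kinase alpha-1 (Homo sapiens), read by mobility shift assay, tested at 30 uM; a lower number here means less inhibition, a higher number more inhibition at the concentration tested (going by the name of the read-out). Compound 1 `Cc1cc2[nH]nc(N)c2c(=O)[nH]1`, which carries only a methyl on the core, gives 6%, the lowest of the two numbers. Compound 2 `CN1CCN(c2ccc(-c3cc4[nH]nc(N)c4c(=O)[nH]3)cc2)CC1`, which carries a larger aromatic group at the same place, gives 26% in this assay, and the gap between the two values lies beyond the usual scatter of repeated measurements.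

Compound 3 `Nc1n[nH]c2cc(-c3cccs3)[nH]c(=O)c12` has not yet been measured in this assay. It differs from compound 1 in one place: thiophen-2-yl in place of methyl on an aromatic carbon. For the measured compounds named here, no measured pair shows exactly this exchange, so the size of the step has to be judged from what is known. The step from compound 1 to compound 3 is expected to be upward, and of moderate size, a number 14 percentage points higher from compound 1 to compound 3 (beyond the scatter). This expectation rests on compound 2, whose aromatic ring at the same place gives 26%, a clearly higher inhibition than the methyl of compound 1.

Compound 3 is therefore estimated to give 20% in this assay, expected to fall between 5% and 40%.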

Compound 3, a percentage reported as inhibition, at one concentration (the size of the read-out at that concentration, not a potency): 35%
For compound 3 the middle estimate is 15 percentage points below the measured one; the range from low to high includes it.
By their numbers in this assay, from the lowest: compound 1; then compounds 2 and 3 (each within the scatter of the next).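

In this assay, putting thiophen-2-yl in place of methyl on this aromatic carbon gives a number 29 percentage points higher from compound 1 to compound 3 (beyond the scatter), so one five-membered aromatic ring with no further group on it is enough to move the read-out beyond the scatter. Compound 2 gives 26% and compound 3 gives 35%, values within the scatter of each other, so the read-out does not separate the larger aromatic group of compound 2 from the smaller thiophen-2-yl. No measurement available here explains the step from methyl to thiophen-2-yl.

The compounds shown leave open whether an aromatic ring is needed at this carbon at all, or whether a non-aromatic group such as an n-butyl chain or a cyclohexyl ring would serve equally well. They also leave open whether the sulfur of the thiophen-2-yl matters, which a comparison with phenyl or furan-2-yl at the same place could address, and every number here remains a read-out at one concentration rather than a potency.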